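Amide substituent step from isopropyl to cyclohexylmethyl

This account rests on a few compounds, and the source may have more. Where it says the series, first, only, none or still open, it means among the compounds named here.

In a functional assay on NIH3T3 cells (Mus musculus) (a lower number here means that less compound is needed, a higher number that more compound is needed for the effect), compound 1 (`CSCC[C@H](NC(=O)c1ccc(NCc2cncn2Cc2ccccc2C#N)cc1-c1ccccc1)C(=O)O`) gives > 10 uM as a limit of the assay and not a number. Compound 2 (`CC(C)NC(=O)c1ccc(NCc2cncn2Cc2ccc(C#N)cc2)cc1-c1ccccc1`) gives > 10 uM which is likewise only a limit. Among the measured compounds shown here, the series so far stands at a single limit (the limit of > 10 uM in this assay, at which 2 of the 2 values shown sit) with no measured step to work from. Compound 3 (`N#Cc1ccc(Cn2cncc2CNc2ccc(C(=O)NCC3CCCCC3)c(-c3ccccc3)c2)cc1`) has cyclohexylmethyl in place of isopropyl on an amide-type nitrogen. The expected change (an at least 1.2-fold lower number from compound 2 to compound 3 (0.09 log units; that floor lies within the scatter)) is small, estimated near the scatter and leaning if anything toward less compound needed. For compound 3 the estimate is 8 uM with an expected range of 2 uM to 30 uM as the half-maximal concentration in this assay for this series.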

Compound 3, concentration for half-maximal effect: > 10 uM
Compound 3 ended at the assay's limit (the forecaster's own chance of this, stated with the estimate: 60%); middle value at least 1.2-fold (0.09 log units) away from the limit.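

Compound 2 and compound 3 both rest at the assay's limit, so no step between them can be read: the limit of > 10 uM in this assay, at which 3 of the 3 values shown sit.

The compounds shown leave open whether cyclohexylmethyl in place of isopropyl changes the concentration needed, and where any true half-maximal value lies.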